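Methoxy for hydrogen: carrying one step over to compound 4

The source may hold more compounds than are shown below. What is called first, only, known or untested is meant among the compounds shown, and "the series" means these compounds.

Compound 1 `Cn1c(=O)c2[nH]c(SCC(=O)c3ccccc3)nc2n(C)c1=O` and compound 2 `COc1ccc(C(=O)CSc2nc3c([nH]2)c(=O)n(C)c(=O)n3C)cc1` share one core, while compound 3 `Cn1c(=O)[nH]c2nc(SC/C(=N/O)c3ccccc3)[nH]c2c1=O` and compound 4 `COc1ccc(/C(CSc2nc3[nH]c(=O)n(C)c(=O)c3[nH]2)=N\O)cc1` share another; how the core of compound 3 differs from the core of compound 1 is not broken down here. In a functional assay on PANC-1 cells (Homo sapiens) for inhibition, read by MTT assay, with a stated time of 48 h (on this read-out lower numbers stand for stronger inhibition and higher numbers for weaker inhibition), compound 1 gives 4900 nM and compound 2 gives 6400 nM under the same conditions. The change between them is methoxy in place of hydrogen on an aromatic carbon and the step it made is a 1.3-fold higher number from compound 1 to compound 2 (0.12 log units; within the scatter) in this assay. Compound 3 gives 3600 nM in this assay. Among the measured compounds shown here, the change from compound 3 to compound 4 is methoxy in place of hydrogen on an aromatic carbon and it is the same change at the same kind of place as the one from compound 1 to compound 2. Because that earlier step was a 1.3-fold higher number from compound 1 to compound 2 (0.12 log units; within the scatter) in this assay, the step expected from the methoxy here is a 1.3-fold higher number from compound 3 to compound 4 (0.12 log units; within the scatter) in this assay. This rests on one prior instance only, itself within the scatter. Compound 4 is therefore estimated at 4700 nM in this assay, with the expected range running from 2500 nM to 9000 nM in this assay.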

Compound 4, half-maximal inhibitory concentration: 1910 nM
For compound 4 the middle estimate is 2.5-fold (0.39 log units) above the measured one; measured number below the stated range.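

The new step of a 1.9-fold lower number from compound 3 to compound 4 (0.28 log units; within the scatter) in this assay stands with the earlier 1.3-fold higher number from compound 1 to compound 2 (0.12 log units; within the scatter) as a second reading of phenyl to 4-methoxyphenyl, now on a different core. The two steps cannot be told apart: the same change on two cores in this assay, a 1.3-fold higher number (0.12 log units; within the scatter) from compound 1 to compound 2 and a 1.9-fold lower number (0.28 log units; within the scatter) from compound 3 to compound 4, 2.5-fold (0.39 log units) apart, within the scatter of two such steps. On these two pairs, methoxy in place of hydrogen stays within the scatter on both cores, but two pairs do not establish a fixed size or direction for the change, nor show that the cores respond alike or differently.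

Going by these compounds, it remains open whether an amine or a carboxylic acid at the same place, para to a large group, would give a step beyond the scatter on either core. On these data alone, a longer chain in place of the methoxy is equally open, as is the contribution of the difference between the two cores, which is not broken down here.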